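The source may report more compounds than this note shows. Statements on the series, on what has been measured and on what is new or still open speak of the compounds shown alone.

Three amides on a shared core have been tested in a functional assay on MCF7 cells (Homo sapiens) for inhibition, read by MTT assay; on this read-out higher numbers stand for weaker inhibition of growth and lower numbers for stronger inhibition of growth: compound 1 `COc1cc2oc(-c3cccc(NC(=O)c4ccccc4Br)c3)cc(=O)c2c(OC)c1OC` gives 55000 nM, compound 2 `COc1cc2oc(-c3cccc(NC(=O)c4ccc([N+](=O)[O-])cc4)c3)cc(=O)c2c(OC)c1OC` gives 20100 nM and compound 3 `COc1cc2oc(-c3cccc(NC(=O)c4ccc(C#N)cc4)c3)cc(=O)c2c(OC)c1OC` gives 12700 nM. Compound 3 sits at the low end of this small set, though not alone, since the nitro and cyano amides are separated only by a 1.6-fold lower number from compound 2 to compound 3 (0.20 log units; within the scatter). The 2-bromophenyl amide stands apart from both, with a 2.7-fold lower number from compound 1 to compound 2 (0.44 log units; beyond the scatter) and a 4.3-fold lower number from compound 1 to compound 3 (0.64 log units; beyond the scatter).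

The next compound, compound 4 `COc1ccc(C(=O)Nc2cccc(-c3cc(=O)c4c(OC)c(OC)c(OC)cc4o3)c2)cc1`, carries methoxy in place of cyano on an aromatic carbon, para to a large group: methoxy in place of cyano on an aromatic carbon. Among the compounds with values here, no measured compound has a methoxy group on this ring, so the data offer only an indirect guide. Within the data shown here, the closest precedent is the exchange of nitro for cyano at the same place, a 1.6-fold lower number from compound 2 to compound 3 (0.20 log units; within the scatter). The two modest steps replace the 2-bromophenyl group as a whole, so they bear on this change less directly. Nothing in the series therefore points to a large move in this assay. The expected step is a 1.6-fold higher number from compound 3 to compound 4 (0.20 log units; within the scatter), which would not clearly exceed the scatter. For compound 4 the estimated value is 20000 nM, with an expected range of 8000 nM to 50000 nM.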

Compound 4, concentration for 50% growth inhibition: 6870 nM
Compound 4: the middle estimate sits 2.9-fold (0.46 log units) above what was measured, and the stated range ends above it.
By their numbers in this assay, from the lowest: compounds 4, 3 and 2 (each within the scatter of the next, the first and the last beyond it); then compound 1.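

At this place on the ring, para to a large group, the result adds a donor-free methoxy to the groups compared in this assay, and exchanging cyano for it gives a 1.8-fold lower number from compound 3 to compound 4 (0.27 log units; within the scatter), so this exchange leaves the number within the scatter even though the atoms attached to the ring differ. Within the data shown here, the comparison with nitro is different, as a 2.9-fold lower number from compound 2 to compound 4 (0.47 log units; beyond the scatter) is the first step beyond the scatter among the groups at this place, and an 8.0-fold lower number from compound 1 to compound 4 (0.90 log units; beyond the scatter) widens the separation of the 2-bromophenyl amide from the other amides, which the earlier compounds showed only at a smaller size. No measurement offered here accounts for these differences.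

The compounds leave open how an amine, a carboxylic acid or a hydroxyl group at the same place would compare with methoxy, cyano and nitro. They also leave open whether the bromine itself or its place on the ring sets compound 1 apart, since the step from that compound changes both the group and where it sits.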